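Amino Replaces Fluoro and Methoxy on the Cinnamide Ring

The compounds below may be only part of what the source reports. "The series", "measured", "known", "first", "only" and "open" are said of these compounds alone.

Three compounds share one core and were tested in a functional assay on HeLa cells (Homo sapiens) for cytotoxicity, read by MTT assay, with a stated time of 72 h; on this read-out higher numbers stand for weaker inhibition and lower numbers for stronger inhibition. Compound 1 `C#CCOc1cccc(/C=C/C(=O)Nc2cc(C(=O)c3cc(OC)c(OC)c(OC)c3)ccc2OC)c1` gives 14000 nM. Compound 2 `COc1ccc(C(=O)c2cc(OC)c(OC)c(OC)c2)cc1NC(=O)/C=C/c1ccc(F)cc1` gives 60 nM. Compound 3 `COc1cc(/C=C/C(=O)Nc2cc(C(=O)c3cc(OC)c(OC)c(OC)c3)ccc2OC)ccc1F` gives 13600 nM. Among these three numbers compound 3 stands second highest: its number and that of compound 1 lie within the scatter of each other, while the step of a 230-fold higher number from compound 2 to compound 3 (2.36 log units; beyond the scatter) is large.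

Compound 4 `COc1ccc(C(=O)c2cc(OC)c(OC)c(OC)c2)cc1NC(=O)/C=C/c1ccc(N)cc1` differs from compound 3 by 4-aminophenyl in place of 4-fluoro-3-methoxyphenyl on a double-bonded chain carbon bound to a double-bonded chain carbon. Within the data shown here, two measured steps bear on this change. Among the measured compounds shown here, the step of a 230-fold higher number from compound 2 to compound 3 (2.36 log units; beyond the scatter) shows that taking the methoxy away from the ring of compound 3 can bring a large fall, and the step of a 230-fold lower number from compound 1 to compound 2 (2.37 log units; beyond the scatter) shows that a ring bearing only one group on it can sit at a low number. For the measured compounds named here, compound 4 likewise carries a single group on that ring, so a large step downward is expected, a 54-fold lower number from compound 3 to compound 4 (1.74 log units; beyond the scatter), though the amino group itself has no measured precedent here and widens the range. Compound 4 is therefore estimated at 250 nM, between 30 nM and 3000 nM.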

Compound 4, half-maximal inhibitory concentration: 14700 nM
Compound 4: the middle estimate sits 59-fold (1.77 log units) below what was measured, outside the stated range (above it).
By their numbers in this assay, from the lowest: compound 2; then compounds 3, 1 and 4 (each within the scatter of the next).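

Swapping one group decides the outcome here: with amino in place of fluoro on an aromatic carbon and nothing else changed, there is a 250-fold higher number from compound 2 to compound 4 (2.39 log units; beyond the scatter), so a single group on this ring does not by itself bring a low number. The amino compound also joins the other two high compounds, with a 1.1-fold higher number from compound 3 to compound 4 (0.03 log units; within the scatter) and a 1.1-fold higher number from compound 1 to compound 4 (0.02 log units; within the scatter), which leaves compound 2 alone at the low end of this set, even though the three other rings carry different groups. No measurement available here gives a reason for this difference.

From the compounds shown here alone, it remains open whether chloro, hydroxy or methyl in place of the fluoro would give a number near that of compound 2 or near that of compound 4. Dimethylamino or acetamido in place of the amino would test whether the high number holds for other nitrogen groups.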